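This account rests on a few compounds, and the source may have more. Where it says the series, first, only, none or still open, it means among the compounds named here.

Working notes on the series. Among the compounds with values here, compound 1 `COc1ccc(OCCCON2C(N)=NC(N)=NC23CCOCC3)cc1` is the only member with a number in hand: in an assay on isolated protein for inhibition of Dihydrofolate reductase (Homo sapiens), read by spectrophotometry, using NADPH, with stated times of 5 s and 6 min (a lower number here means a stronger inhibitor, a higher number a weaker inhibitor), compound 1 gives 11.1 nM. Compound 2 `NC1=NC2(CCSCC2)N(OCCCOc2ccccc2Br)C(N)=N1` belongs to the same set, but for compound 2 in this assay the entry reads "not determined" (no result reported), so it offers no point of comparison. Compound 3 `Cc1ccc(OCCCON2C(N)=NC(N)=NC23CCOCC3)cc1` has not been measured in this assay.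

The change from compound 1 to compound 3 is confined to one position: methyl in place of methoxy on an aromatic carbon. Nothing else in the structure moves.

With no measured pair of this kind in the series, there is no step to lean on. The expectation for this assay is a step of a 1.4-fold higher number from compound 1 to compound 3 (0.13 log units; within the scatter), which is small and lies within the usual scatter rather than a real shift in either direction. Compound 3 is therefore estimated at 15 nM, in the range 6 nM to 40 nM.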

Compound 3, half-maximal inhibitory concentration: 56.8 nM
Compound 3: middle estimate off by 3.8-fold (0.58 log units), on the low side, outside the stated range (above it).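

In this assay this position, para to a large group, responds to the substituent: methyl in place of methoxy gives a 5.1-fold higher number from compound 1 to compound 3 (0.71 log units; beyond the scatter) and so makes 4-methoxyphenyl the stronger of the two aryl groups here. Within the data shown here, this is the first measured one-place step, and it shows that a change of a single group on the aromatic carbon is enough to move the number beyond the scatter while the shared core and the chain stay fixed. No accompanying measurement bears on why the step has this size.

A single pair cannot show whether the oxygen of methoxy or some other feature of the group carries the difference. Ethoxy, hydroxyl, chlorine or an amine at the same place would help to separate these readings, and the rest of the chain and the core remain open as well.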